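Alkylsulfanyl Chain Length and Spleen Activation in Mouse

The source may hold more compounds than are shown below. What is called first, only, known or untested is meant among the compounds shown, and "the series" means these compounds.

Measured compounds:
compound 1 `CCSc1nc(N)c2nc(O)n(Cc3ccccc3)c2n1` gives 0.1 uM
compound 2 `CCCCSc1nc(N)c2nc(O)n(Cc3ccccc3)c2n1` gives 0.01 uM
compound 3 `Nc1ncnc2c1nc(O)n2Cc1ccccc1` gives 10 uM

In a functional assay (spleen, spleen) for activation, with Mus musculus as the target (a lower number here means that less compound is needed, a higher number that more compound is needed for the effect), compound 3 stands highest of the three numbers, with compound 1 the nearest and compound 2 the furthest below it. Compound 4 `CCCCCSc1nc(N)c2nc(O)n(Cc3ccccc3)c2n1` has not yet been measured. It differs from compound 3 by pentylsulfanyl in place of hydrogen on an aromatic carbon.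

Among the measured compounds shown here, two measured steps bear directly on this change. Going from compound 1 to compound 3, a 100-fold higher number from compound 1 to compound 3 (2.00 log units; beyond the scatter), and from compound 2 to compound 3, a 1000-fold higher number from compound 2 to compound 3 (3.00 log units; beyond the scatter); in both an alkylsulfanyl group is replaced by hydrogen and the number rises sharply. The step of a 10-fold lower number from compound 1 to compound 2 (1.00 log units; beyond the scatter) shows that the longer chain carries the lower number. Pentylsulfanyl is longer again than butylsulfanyl, so a large step downward is expected, a 2000-fold lower number from compound 3 to compound 4 (3.30 log units; beyond the scatter), although no measured pair covers pentylsulfanyl itself and the lengthening trend rests on only two compounds. Compound 4 is therefore estimated at 0.005 uM, with a range from 0.001 uM to 0.03 uM.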

Compound 4, minimum effective concentration: 10 uM
For compound 4 the middle estimate is 2000-fold (3.30 log units) below the measured one; measured number above the stated range.
By their numbers in this assay, from the lowest: compound 2; then compound 1; then compounds 3 and 4 (each within the scatter of the next).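

In this assay there is no change at the digits printed from compound 3 to compound 4 (within the scatter) when pentylsulfanyl replaces hydrogen on the aromatic carbon between two ring nitrogen atoms, so a sulfur-linked chain at this position does not by itself lower the number. The one extra methyl at the end of the chain gives a 1000-fold higher number from compound 2 to compound 4 (3.00 log units; beyond the scatter) and, set against the ethyl chain, the pentyl chain gives a 100-fold higher number from compound 1 to compound 4 (2.00 log units; beyond the scatter), so the fall in the number from ethylsulfanyl to butylsulfanyl does not continue to pentylsulfanyl, and compound 4 goes against any simple rule that longer is better. Nothing available explains this sharp reversal over a single added carbon.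

On these data alone, how propylsulfanyl or hexylsulfanyl would stand here remains open, and so does whether the effect belongs to the chain's length alone. A branched chain such as isopentylsulfanyl, or an amine in place of the sulfur, would bear on that.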